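Aryl amide series: microsomal clearance from compound 2 to compound 3

A few compounds are considered here, and "the series" means these few. Any claim that something is new, unique, unknown or untested is made for them only; others in the source may bear on it.

Measured so far:
- compound 1 `Cc1cc(C)c(-c2c[nH]nc2C)cc1NC(=O)c1ccc(OCc2ccccn2)cc1`: in an ADME assay on microsomes from liver (Homo sapiens) for metabolic stability (on this read-out higher numbers stand for fast clearance and lower numbers for slow clearance), compound 1 gives 20 mL.min-1.g-1
- compound 2 `Cc1cc(C)c(-c2cccnc2)cc1NC(=O)c1ccc(OCc2ccccn2)cc1`: in this assay compound 2 gives 62 mL.min-1.g-1

Going by the values given here, compound 2 stands at the highest of the two numbers so far; its nearest neighbour is compound 1, and the step of a 3.1-fold higher number from compound 1 to compound 2 (0.49 log units; beyond the scatter) separates the two, which is beyond the scatter.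

Compound 3 `Cc1cc(C)c(-c2cccc(N)n2)cc1NC(=O)c1ccc(OCc2ccccn2)cc1` has not yet been measured in this assay. The change is 6-aminopyridin-2-yl in place of pyridin-3-yl on an aromatic carbon. Among the compounds with values here, no measured step covers this change: the only step in hand, a 3.1-fold higher number from compound 1 to compound 2 (0.49 log units; beyond the scatter), concerns a different ring exchange at the same aromatic carbon and gives no direct guide to an aminopyridine. On that basis no step beyond the scatter is expected, and the estimate for compound 3 is set close to compound 2, leaning slightly lower, as a 1.4-fold lower number from compound 2 to compound 3 (0.14 log units; within the scatter). Compound 3 is therefore expected to give about 45 mL.min-1.g-1, within a range from 15 mL.min-1.g-1 to 110 mL.min-1.g-1.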

Compound 3, intrinsic clearance in microsomes: 88 mL.min-1.g-1
The estimate for compound 3 lay 2.0-fold (0.29 log units) below the measured number; the range from low to high includes it.
By their numbers in this assay, from the lowest: compound 1; then compounds 2 and 3 (each within the scatter of the next).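

In this assay, replacing pyridin-3-yl with 6-aminopyridin-2-yl gives a 1.4-fold higher number from compound 2 to compound 3 (0.15 log units; within the scatter), so at this aromatic carbon, a change in the ring's attachment point together with an added amino group does not separate the two compounds. The contrast with the 3-methyl-1H-pyrazol-4-yl compound extends to this second six-membered ring, with a 4.4-fold higher number from compound 1 to compound 3 (0.64 log units; beyond the scatter); among the three compounds, compound 1 alone stands apart from the others. Nothing in hand bears on the origin of these differences.

On these data alone, because the exchange alters attachment point and amino substitution together, the contribution of each stays open. A plain pyridin-2-yl group would separate them, while a 6-methoxypyridin-2-yl group would test whether another substituent at that ring position reads the same.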